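Swapping the ring on the amine: from compound 2 to compound 3

This account rests on a few compounds, and the source may have more. Where it says the series, first, only, none or still open, it means among the compounds named here.

Measured so far:
compound 1 `OC[C@@H](O[C@H]1CCCN(Cc2ncc[nH]2)[C@H]1c1ccccc1)c1cc(Cl)cc(Cl)c1` — in an assay on HEK293 cells for activation of cGMP-dependent protein kinase 1 (Homo sapiens), read by HTRF, with a stated time of 3 h (on this read-out lower numbers stand for an effect already at smaller amounts and higher numbers for an effect only at larger amounts of compound), compound 1 gives 8800 nM
compound 2 `OC[C@@H](O[C@H]1CCCN(Cc2cccc3nonc23)[C@H]1c1ccccc1)c1cc(Cl)cc(Cl)c1` — in this assay compound 2 gives 141000 nM

Going by the values given here, compound 2 stands at the highest number of the two measured, with compound 1 as its only neighbour; the step from one to the other is large, a 16-fold higher number from compound 1 to compound 2 (1.20 log units; beyond the scatter), and comes from exchanging the ring carried on the saturated chain carbon bound to the amine nitrogen in the ring.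

Compound 3 `O=C(O)c1ccc2c(CN3CCC[C@H](O[C@H](CO)c4cc(Cl)cc(Cl)c4)[C@@H]3c3ccccc3)c[nH]c2c1` is not yet measured. It differs from compound 2 at that same carbon: a group of 12 heavy atoms (9 carbon, 1 nitrogen, 2 oxygen; one five-membered aromatic ring with 1 hetero atom, one six-membered aromatic ring of carbon only) in place of a group of 9 heavy atoms (6 carbon, 2 nitrogen, 1 oxygen; one five-membered aromatic ring with 3 hetero atoms, one six-membered aromatic ring of carbon only), on a saturated chain carbon bound to an amine nitrogen in a ring. Among the compounds with values here, the only measured step that touches this position is the one from compound 1 to compound 2, which shows that the choice of ring there moves the number a great deal, while telling nothing about the new group itself.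

Within the data shown here, since the single measured step at this position was large in both size and consequence, a clear shift from compound 2 is expected rather than a standstill. Compound 3 is estimated at 15000 nM in this assay, a step of a 9.4-fold lower number from compound 2 to compound 3 (0.97 log units; beyond the scatter), with a likely range from 3000 nM to 80000 nM.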

Compound 3, half-maximal effective concentration: 140000 nM
Compound 3: the middle estimate sits 9.3-fold (0.97 log units) below what was measured, and the stated range ends below it.
By their numbers in this assay, from the lowest: compound 1; then compounds 3 and 2 (each within the scatter of the next).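

In this assay, putting 6-carboxy-1H-indol-3-yl on the saturated chain carbon bound to an amine nitrogen in a ring gives a 1.0-fold lower number from compound 2 to compound 3 (0.00 log units; within the scatter), so two groups that differ in their rings and hetero atoms cannot be told apart here. Measured against the 1H-imidazol-2-yl group, the new group gives a 16-fold higher number from compound 1 to compound 3 (1.20 log units; beyond the scatter), a step that matches a 16-fold higher number from compound 1 to compound 2 (1.20 log units; beyond the scatter) and shows that the high number at this position is not confined to the group of compound 2, with both groups of two rings lying well above the single-ring group and neither compound going against this among the three shown. Nothing measured here explains why the three groups fall as they do.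

These compounds leave open whether 1H-indol-3-yl without its carboxylic acid, or with a methyl ester or a primary amide in that acid's place, would stay with compound 3 or move towards compound 1. They also leave open whether a different single ring on the same carbon, such as pyridin-2-yl or 1H-pyrazol-3-yl, would keep the number of compound 1 or lose it.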